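Solubility notes on ester-linked analogues of a shared core

A few compounds are considered here, and "the series" means these few. Any claim that something is new, unique, unknown or untested is made for them only; others in the source may bear on it.

Measured so far:
compound 1 `COc1ccc2c(c1)c(CC(=O)OCOC(=O)C(C)(C)C)c(C)n2C(=O)c1ccc(Cl)cc1` — 0.084 ug/mL
compound 2 `COc1ccc2c(c1)c(CC(=O)OCOC(=O)OC(C)C)c(C)n2C(=O)c1ccc(Cl)cc1` — 0.119 ug/mL
compound 3 `COc1ccc2c(c1)c(CC(=O)OCCOC(C)=O)c(C)n2C(=O)c1ccc(Cl)cc1` — 0.111 ug/mL

In a physicochemical assay for solubility, read by HPLC, in phosphate buffer, with a stated time of 4 h, at pH 7.4 (a higher number here means a more soluble compound, a lower number a less soluble compound), compound 1 gives 0.084 ug/mL, compound 2 gives 0.119 ug/mL and compound 3 gives 0.111 ug/mL. Compound 3 sits within the scatter of both neighbours: a 1.3-fold higher number from compound 1 to compound 3 (0.12 log units; within the scatter) and a 1.1-fold lower number from compound 2 to compound 3 (0.03 log units; within the scatter). The three numbers therefore cannot be ordered.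

Compound 4 `COc1ccc2c(c1)c(CC(=O)OCc1oc(=O)oc1C)c(C)n2C(=O)c1ccc(Cl)cc1` is not yet measured in this assay. It differs from compound 3 by a group of 7 heavy atoms (4 carbon, 3 oxygen; one five-membered aromatic ring with 2 hetero atoms) in place of a group of 5 heavy atoms (3 carbon, 2 oxygen; no ring), on a saturated chain carbon bound to an oxygen next to a carbonyl group. The same place has already been varied twice among the measured compounds: a 1.3-fold higher number from compound 1 to compound 3 (0.12 log units; within the scatter) and a 1.1-fold lower number from compound 2 to compound 3 (0.03 log units; within the scatter), and neither step left the scatter. Within the data shown here, the group that enters in compound 4 is larger than the one it replaces and carries a ring, which none of the earlier variants at this place did, so the earlier steps are only a partial guide. On them, no step beyond the scatter is expected, and the estimate for compound 4 in this assay is 0.11 ug/mL, with a range of 0.05 ug/mL to 0.25 ug/mL. This estimate means a 1.0-fold lower number from compound 3 to compound 4 (0.00 log units; within the scatter).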

Compound 4, solubility: 0.0638 ug/mL
For compound 4 the middle estimate is 1.7-fold (0.24 log units) above the measured one; low and high end bracket the measured number.
By their numbers in this assay, from the lowest: compounds 4, 1, 3 and 2 (each within the scatter of the next).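

In this assay, compound 4 brings the first ring to this saturated chain carbon, yet all three new steps stay within the scatter (a 1.7-fold lower number from compound 3 to compound 4 (0.24 log units; within the scatter)) and (a 1.9-fold lower number from compound 2 to compound 4 (0.27 log units; within the scatter)) and (a 1.3-fold lower number from compound 1 to compound 4 (0.12 log units; within the scatter)). The four groups compared at this place, one with a five-membered aromatic ring and three with no ring, therefore give numbers that cannot be ordered, and the ring does not set compound 4 apart from the other three compounds. Nothing available bears on what lies behind these numbers.

As far as these compounds go, whether an amine or a carboxylic acid at this place, or a longer chain, would give a step beyond the scatter remains open. Also open, from the compounds shown here alone, is whether the same exchanges would stay within the scatter on a core other than the shared one.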